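Fluoro for Methyl on the Aryl Ring of Compound 3

A few compounds are considered here, and "the series" means these few. Any claim that something is new, unique, unknown or untested is made for them only; others in the source may bear on it.

Compound 3 `Cc1ccc(C2SCC(=O)N2CCN2CCCCC2)cc1` gives 100% in an ADME assay on Vero cells (Chlorocebus sabaeus) for cytotoxicity, read by neutral red uptake, tested at 98 ug/mL; a lower number here means a stronger effect, a higher number a weaker effect of the compound at the concentration tested. Compound 2 `O=C1CSC(c2cccc(Cl)c2)N1CCN1CCCCC1` gives 100% in this assay, so the two stand level and together are the highest of the three numbers. For the measured compounds named here, compound 1 `COc1ccc(C2SCC(=O)N2CCN2CCCCC2)cc1` gives 89%, and the step of a number 11 percentage points higher from compound 1 to compound 3 (beyond the scatter) is the only change beyond the scatter seen so far, while the step of no change at the digits printed from compound 2 to compound 3 (within the scatter) left the number unchanged.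

Compound 4 `O=C1CSC(c2ccc(F)cc2)N1CCN1CCCCC1` differs from compound 3 in one place: fluoro in place of methyl on an aromatic carbon. Both measured steps alter the same aryl substituent, one modestly and one not at all, and none involves fluoro. Compound 4 is therefore expected to stay near the top, with the step of a number 4 percentage points lower from compound 3 to compound 4 (within the scatter) estimated to lie within the scatter, giving 96% (range 84% to 100%).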

Compound 4, a percentage reported as activity, at one concentration (the size of the read-out at that concentration, not a potency): 87%
Compound 4: the middle estimate sits 9 percentage points above what was measured; low and high end bracket the measured number.
By their numbers in this assay, from the lowest: compounds 4 and 1 (each within the scatter of the next); then compounds 2 and 3 (each within the scatter of the next).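

In this assay, fluoro on the aromatic carbon para to a large group does not hold the level of methyl: the change gives a number 13 percentage points lower from compound 3 to compound 4 (beyond the scatter) and joins methoxy, since fluoro in place of methoxy gives a number 2 percentage points lower from compound 1 to compound 4 (within the scatter) with no separation between the two. The swap of 3-chlorophenyl for 4-fluorophenyl gives a number 13 percentage points lower from compound 2 to compound 4 (beyond the scatter) and so the level shared by compound 2 and compound 3 does not extend to every substituted phenyl in this set. Nothing available explains why fluoro and methyl part here.

Going by these compounds, how a nitrile or a trifluoromethyl group would read at this position remains open, as does the unsubstituted phenyl.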